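Thioether side chain trimming in a pyrazolopyrimidinone series

The compounds below may be only part of what the source reports. "The series", "measured", "known", "first", "only" and "open" are said of these compounds alone.

Measured so far in an assay on isolated protein for inhibition of Retinaldehyde dehydrogenase 3 (Homo sapiens); a lower number here means a stronger inhibitor, a higher number a weaker inhibitor:
- compound 1, `Cn1ncc2c(=O)n(-c3ccccc3)c(SC(C)(C)c3ccccc3)nc21`, gives 1390 nM
- compound 2, `COc1cccc(C(C)Sc2nc3c(cnn3C)c(=O)n2-c2ccccc2)c1`, gives 174 nM
- compound 3, `CCC(Sc1nc2c(cnn2C)c(=O)n1-c1ccccc1)c1ccccc1`, gives 119 nM

Compound 3 shows the lowest of the three numbers; compound 2 lies within the scatter of it, so the two are not separable, while compound 1 stands well apart. Among the measured compounds shown here, the only one-place step, a 12-fold lower number from compound 1 to compound 3 (1.07 log units; beyond the scatter), is a large gain on removing a methyl from the chain carbon that carries the sulfur.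

Compound 4, `CC(Sc1nc2c(cnn2C)c(=O)n1-c1ccccc1)c1ccccc1`, is not yet measured. It differs from compound 3 by hydrogen in place of methyl on a saturated chain carbon, two bonds along the chain from an aromatic carbon and a sulfur. This is again a loss of one methyl on the side chain, but cut one bond further out than in the measured step, so that step bears on it only loosely. Compound 2, which carries a shorter side chain of the same type, sits within the scatter of compound 3, which argues for a small shift at most. For compound 4 a step of a 1.5-fold higher number from compound 3 to compound 4 (0.18 log units; within the scatter) is therefore expected, and its value in this assay is estimated at 180 nM, between 80 nM and 400 nM.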

Compound 4, half-maximal inhibitory concentration: 73 nM
Estimate against measurement, compound 4: 2.5-fold (0.39 log units) above; measured number below the stated range.
By their numbers in this assay, from the lowest: compounds 4, 3 and 2 (each within the scatter of the next, the first and the last beyond it); then compound 1.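

In this assay, ethyl to methyl on the carbon bearing the sulfur, 1-phenylpropyl to 1-phenylethyl, gives a 1.6-fold lower number from compound 3 to compound 4 (0.21 log units; within the scatter) and so cannot be told apart from no change, while hydrogen in place of methoxy on an aromatic carbon gives a 2.4-fold lower number from compound 2 to compound 4 (0.38 log units; beyond the scatter) as a modest step, which shows that the methoxy of compound 2 brings no gain here. The large step seen earlier with 1-phenylpropyl also appears with 1-phenylethyl, as a 19-fold lower number from compound 1 to compound 4 (1.28 log units; beyond the scatter) in place of 1-methyl-1-phenylethyl, so the cost of the extra methyl in compound 1 holds for both chains. Nothing on hand accounts for these steps.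

Still open, from the compounds shown here alone, is whether a plain benzyl chain, with hydrogen in place of the remaining methyl, holds the value of compound 4. Also open, going by these compounds, is how an amine or a chlorine on the side-chain phenyl ring would read.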